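The source may hold more compounds than are shown below. What is called first, only, known or untested is meant among the compounds shown, and "the series" means these compounds.

Three compounds have been measured in a functional assay on CHO cells for agonist activity at Alpha-2B adrenergic receptor (Homo sapiens); on this read-out lower numbers stand for smaller maximal responses and higher numbers for larger maximal responses:
Compound 1, `Cc1ccc(-c2ccccc2OC(C)C2=NCCN2)cc1`, gives the limit < 0.3.
Compound 2, `CC(Oc1ccccc1-c1ccccc1O)C1=NCCN1`, gives the limit < 0.3.
Compound 3, `Cc1ccccc1-c1ccccc1OC(C)C1=NCCN1`, gives the limit < 0.3.

Each of these values is a limit of this assay and not a number. Compound 3 therefore stands only at that limit, and the steps leading to it cannot be read: a step that the two limits leave unreadable from compound 1 to compound 3 and a step that the two limits leave unreadable from compound 2 to compound 3. The step that the two limits leave unreadable from compound 1 to compound 2 is equally unreadable. All three values sit at one place, described by the limit of < 0.3 in this assay, at which 3 of the 3 values shown sit.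

Compound 4, `Cc1cccc(-c2ccccc2OC(C)C2=NCCN2)c1`, has not been measured. It differs from compound 3 in one place: 3-methylphenyl in place of 2-methylphenyl on an aromatic carbon. Among the measured compounds shown here, the measured steps that bear on this change are the two into compound 3 and the one between compound 1 and compound 2, and none of them has a readable size, because every value involved sits at the limit (the limit of < 0.3 in this assay, at which 3 of the 3 values shown sit). No direction can be drawn from them. The expectation for compound 4 in this assay is that it will most likely return the limit rather than a number, so the step that the limit leaves unreadable from compound 3 to compound 4 is estimated as none beyond the scatter. Compound 4 is estimated at 0.15, between 0 and 0.3.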

Compound 4, intrinsic activity: the largest response reached, as a fraction of the reference agonist's: < 0.3
Compound 4: no number, only a limit (the forecaster's own chance of this, stated with the estimate: 80%); the middle value is on the limit's open side.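

In this assay, compound 4 gives < 0.3, which is a limit and not a number. Its steps from compound 1, compound 2 and compound 3 therefore cannot be read, as all four compounds sit at one place: the limit of < 0.3 in this assay, at which 4 of the 4 values shown sit.

The compounds shown leave open whether exchanging one of these aromatic groups for another changes the maximal response in this assay at all.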